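Cytotoxicity notes: fluoro in place of benzamido

The source may report more compounds than this note shows. Statements on the series, on what has been measured and on what is new or still open speak of the compounds shown alone.

Measured compounds, each at a limit of the read-out:
Compound 1 `COc1ccc(C2=C(c3cc(OC)c(OC)c(OC)c3)C(=O)C(O)C2)cc1NC(=O)c1ccccc1` gives > 100 ug/mL in an ADME assay on L132 cells (Homo sapiens) for cytotoxicity, read by MTT assay, with a stated time of 72 h; on this read-out lower numbers stand for stronger inhibition and higher numbers for weaker inhibition.
Compound 2 `CCOC(=O)COc1ccc(C2=C(c3cc(OC)c(OC)c(OC)c3)C(=O)CC2O)cc1` gives > 100 ug/mL in this assay.
Compound 3 `COc1cc(C2=C(c3cc(C)c(OC)c(C)c3)C(O[SiH2]C(C)(C)C)CC2=O)cc(OC)c1OC` gives > 100 ug/mL in this assay.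

Compound 1 therefore stands nowhere within the scale: its value is a limit, not a number. The same holds for the two other compounds, and all three share (the limit of > 100 ug/mL in this assay, at which 3 of the 3 values shown sit), so no ranking among them can be drawn.

Compound 4 `COc1ccc(C2=C(c3cc(OC)c(OC)c(OC)c3)C(=O)C(O)C2)cc1F` differs from compound 1 by fluoro in place of benzamido on an aromatic carbon. Among the compounds with values here, no step between measured compounds is available, so the size of this change in this assay is unknown; with every value shown resting at the limit, no step beyond the scatter is expected in either direction. Compound 4 is thus estimated at 100 ug/mL, within 50 ug/mL to 200 ug/mL, which means an expected step of a number no higher from compound 1 to compound 4 (the limit leaves the size open).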

Compound 4, half-maximal inhibitory concentration: < 1 ug/mL
Compound 4 ended at the assay's limit; the forecaster's own chance of this, stated with the estimate: 85%; at least 100-fold (2.00 log units) between middle value and limit.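

On this aromatic carbon, ortho to a methoxy group, fluoro in place of benzamido gives an at least 100-fold lower number from compound 1 to compound 4 (2.00 log units; beyond the scatter) in this assay, and both values behind that step are limits, not numbers. The group on this one carbon can therefore take the core of compound 1 from one end of the read-out to the other, which the earlier compounds could not show: the limit of > 100 ug/mL in this assay, at which 3 of the 4 values shown sit. Compound 4 alone sits at the opposite end: the limit of < 1 ug/mL in this assay, at which 1 of the 4 values shown sits.

Where an amine, a chloro group or an acetamido group on this carbon would fall remains open. On these data alone, the actual number for compound 4 also remains open.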